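The source may hold more compounds than are shown below. What is called first, only, known or untested is meant among the compounds shown, and "the series" means these compounds.

Working notes on the series, read in a functional assay on HepG2 cells (Homo sapiens) for inhibition, read by MTT assay; a higher number here means a weaker inhibitor of growth, a lower number a stronger inhibitor of growth. Within the data shown here, three amides on a shared core have numbers so far: compound 1 (`COc1cc2oc(-c3cccc(NC(=O)c4ccc(Br)cc4)c3)cc(=O)c2c(OC)c1OC`) gives 8850 nM, compound 2 (`COc1cc2oc(-c3cccc(NC(=O)c4cccc(Br)c4)c3)cc(=O)c2c(OC)c1OC`) gives 10900 nM, and compound 3 (`COc1cc2oc(-c3cccc(NC(=O)c4cccc(C#N)c4)c3)cc(=O)c2c(OC)c1OC`) gives 11900 nM. Compound 2 lies within the scatter of both other values.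

Next is compound 4 (`COc1cc2oc(-c3cccc(NC(=O)c4ccc(C(F)(F)F)cc4)c3)cc(=O)c2c(OC)c1OC`), with 4-(trifluoromethyl)phenyl in place of 3-bromophenyl on a carbonyl carbon.

Among the measured compounds shown here, three measured steps bear on this change: a 1.2-fold higher number from compound 1 to compound 2 (0.09 log units; within the scatter), a 1.3-fold higher number from compound 1 to compound 3 (0.13 log units; within the scatter) and a 1.1-fold higher number from compound 2 to compound 3 (0.04 log units; within the scatter). Each stays within the scatter, and each alters the same aryl group on the carbonyl carbon. For the measured compounds named here, no trifluoromethyl example has been measured, so the expectation is an extrapolation from bromo and cyano examples.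

No step beyond the scatter is expected in this assay. The expected step is a 1.1-fold lower number from compound 2 to compound 4 (0.04 log units; within the scatter). Compound 4 is estimated at 10000 nM, with an expected range of 5000 nM to 20000 nM.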

Compound 4, concentration for 50% growth inhibition: 61100 nM
Beside the measured number, compound 4's estimate is 6.1-fold (0.79 log units) below it, and the stated range ends below it.
By their numbers in this assay, from the lowest: compounds 1, 2 and 3 (each within the scatter of the next); then compound 4.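

In this assay the aryl group on the carbonyl carbon shows its first steps beyond the scatter: 4-(trifluoromethyl)phenyl gives a 5.6-fold higher number from compound 2 to compound 4 (0.75 log units; beyond the scatter) and a 5.1-fold higher number from compound 3 to compound 4 (0.71 log units; beyond the scatter). The closest comparison, which swaps only the bromo substituent for a trifluoromethyl group, gives a 6.9-fold higher number from compound 1 to compound 4 (0.84 log units; beyond the scatter), so this group's identity matters here even though the bromo and cyano examples could not be told apart. No measurement shown accounts for the loss of growth inhibition.

The compounds shown leave open whether the step goes with trifluoromethyl itself or only with 4-(trifluoromethyl)phenyl, and 3-(trifluoromethyl)phenyl on the same carbonyl carbon would separate the two. A plain phenyl, a 4-methoxyphenyl or a 4-aminophenyl there would show how far the numbers range across other groups.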